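The source may hold more compounds than are shown below. What is called first, only, known or untested is meant among the compounds shown, and "the series" means these compounds.

Measured in a functional assay for activation of Alpha-1D adrenergic receptor (Homo sapiens); on this read-out lower numbers stand for an effect already at smaller amounts and higher numbers for an effect only at larger amounts of compound: compound 1 `c1coc(-c2ccccc2NCC2=NCCN2)c1`, 16.2 nM; compound 2 `c1csc(-c2ccccc2NCC2=NCCN2)c1`, 18.2 nM; compound 3 `Cc1ccsc1-c1ccccc1NCC1=NCCN1`, 49 nM.

Compound 3 stands highest of the three numbers: its nearest neighbour is compound 2 (a 2.7-fold higher number from compound 2 to compound 3 (0.43 log units; beyond the scatter)) and the furthest is compound 1 (a 3.0-fold higher number from compound 1 to compound 3 (0.48 log units; beyond the scatter)). Compound 4 `Cc1noc(-c2ccccc2NCC2=NCCN2)n1` differs from compound 3 by 3-methyl-1,2,4-oxadiazol-5-yl in place of 3-methylthiophen-2-yl on an aromatic carbon. Among the compounds with values here, the steps that bear on this change all touch the same five-membered ring: a 1.1-fold higher number from compound 1 to compound 2 (0.05 log units; within the scatter) exchanged one hetero atom for another, while a 2.7-fold higher number from compound 2 to compound 3 (0.43 log units; beyond the scatter) added the methyl. Neither alters the ring as deeply as this change does, so the expectation is loosely anchored. A further modest rise in the number is expected for compound 4, a 1.8-fold higher number from compound 3 to compound 4 (0.26 log units; within the scatter), giving an estimate of 90 nM, within a range of 20 nM to 400 nM.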

Compound 4, half-maximal effective concentration: < 5020 nM
Compound 4: no number, only a limit; the forecaster's own chance of this, stated with the estimate: 10%; the middle value is on the limit's open side.
By their numbers in this assay, from the lowest: compounds 1 and 2 (each within the scatter of the next); then compound 3.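

In this assay compound 4 gives only a limit, < 5020 nM, and not a number. Its steps from compound 1, compound 2 and compound 3 cannot be read. On these data alone, whether 3-methyl-1,2,4-oxadiazol-5-yl keeps the number of compound 4 near theirs or far from them stays open.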